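A few compounds are considered here, and "the series" means these few. Any claim that something is new, unique, unknown or untested is made for them only; others in the source may bear on it.

Compound 3 `CNC(=O)c1oc2nc(-c3cccs3)cc(C(F)(F)F)c2c1N` and compound 1 `CNC(=O)c1oc2nc(-c3ccccc3)cc(C(F)(F)F)c2c1N` share a core and differ by phenyl in place of thiophen-2-yl on an aromatic carbon. In a functional assay on HepG2 cells (Homo sapiens) for antiproliferative activity, read by MTT assay (on this read-out higher numbers stand for weaker inhibition and lower numbers for stronger inhibition), compound 3 gives 12300 nM and compound 1 gives 41200 nM, a step of a 3.3-fold higher number from compound 3 to compound 1 (0.52 log units; beyond the scatter). Compound 2 `Nc1c(C(=O)N/N=C/c2ccc(Cl)cc2)oc2nc(-c3cccs3)cc(C(F)(F)F)c12` differs from compound 3 by a group of 9 heavy atoms (7 carbon, 1 nitrogen, 1 chlorine; one six-membered aromatic ring of carbon only) in place of one carbon atom, on an amide-type nitrogen; in this assay compound 2 gives 8100 nM, a step of a 1.5-fold higher number from compound 2 to compound 3 (0.18 log units; within the scatter). Compound 4 `Nc1c(C(=O)N/N=C/c2ccc(Cl)cc2)oc2nc(-c3ccccc3)cc(C(F)(F)F)c12` is not yet measured. It differs from compound 2 by phenyl in place of thiophen-2-yl on an aromatic carbon, the same change as that from compound 3 to compound 1, made on the core of compound 2 rather than that of compound 3. Because the earlier step was a 3.3-fold higher number from compound 3 to compound 1 (0.52 log units; beyond the scatter), compound 4 is expected to show a step of a 3.2-fold higher number from compound 2 to compound 4 (0.51 log units; beyond the scatter) in this assay, close to the size of the earlier one. The estimate for compound 4 in this assay is therefore 26000 nM, expected between 10000 nM and 65000 nM.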

Compound 4, half-maximal inhibitory concentration: 12100 nM
Beside the measured number, compound 4's estimate is 2.1-fold (0.33 log units) above it, and the stated range covers the measured number.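

In this assay, phenyl in place of thiophen-2-yl gives a 1.5-fold higher number from compound 2 to compound 4 (0.17 log units; within the scatter), and this step cannot be told apart from the one seen on the core of compound 3: the same change on two cores in this assay, a 3.3-fold higher number (0.52 log units; beyond the scatter) from compound 3 to compound 1 and a 1.5-fold higher number (0.17 log units; within the scatter) from compound 2 to compound 4, 2.2-fold (0.35 log units) apart, within the scatter of two such steps. The larger group on the amide-type nitrogen gives a 3.4-fold lower number from compound 1 to compound 4 (0.53 log units; beyond the scatter), and this step likewise agrees with its counterpart on the thiophene-bearing core: the same change on two cores in this assay, a 1.5-fold higher number (0.18 log units; within the scatter) from compound 2 to compound 3 and a 3.4-fold higher number (0.53 log units; beyond the scatter) from compound 4 to compound 1, 2.2-fold (0.35 log units) apart, within the scatter of two such steps. The change therefore carries over between these two cores as far as the data can tell, but a single pair on each core does not show that its size is preserved, and the estimate rests on one earlier step only.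

The compounds shown leave open whether a furan-2-yl or a pyridyl ring on that aromatic carbon would behave the same way. They also leave open whether an amine or a carboxylic acid in place of the chlorine would do so.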